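Adding a Second Fluorine to the Triazole-Linked Phenyl Ring

A few compounds are considered here, and "the series" means these few. Any claim that something is new, unique, unknown or untested is made for them only; others in the source may bear on it.

Of the compounds shown here, three sharing one core have been measured in a functional assay on MKN-45 cells (Homo sapiens) for cytotoxicity, read by MTT assay, with a stated time of 72 h; on this read-out lower numbers stand for stronger inhibition and higher numbers for weaker inhibition. Compound 2 `COc1cc2c(Oc3ccc(NC(=O)c4cn(-c5ccccc5)nn4)cc3F)ccnc2cc1OCCCN1CCN(C)CC1` gives 60 nM. Compound 3 `COc1cc2c(Oc3ccc(NC(=O)c4cn(-c5ccccc5F)nn4)cc3F)ccnc2cc1OCCCN1CCN(C)CC1` gives 140 nM, and compound 1 `COc1cc2c(Oc3ccc(NC(=O)c4cn(-c5ccc(F)c(F)c5)nn4)cc3F)ccnc2cc1OCCCN1CCCCC1` gives 310 nM. Among the compounds with values here, on these numbers compound 3 stands second highest of the three, and the step from compound 2 to compound 3, a 2.3-fold higher number from compound 2 to compound 3 (0.37 log units; beyond the scatter), is the only change measured in a single place.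

Compound 4 `COc1cc2c(Oc3ccc(NC(=O)c4cn(-c5ccc(F)c(F)c5)nn4)cc3F)ccnc2cc1OCCCN1CCN(C)CC1` differs from compound 3 by 3,4-difluorophenyl in place of 2-fluorophenyl on an aromatic nitrogen. Within the data shown here, no measured step reproduces this exact exchange. Among the measured compounds shown here, the one step that touches the same ring, from compound 2 to compound 3, shows that one fluorine on this ring raised the number by a modest amount beyond the scatter. Compound 1 carries the same 3,4-difluorophenyl as compound 4 but a different chain end, and compound 1 gives 310 nM, above the number for compound 3. Taken together, a small rise in this assay is expected, with a 1.4-fold higher number from compound 3 to compound 4 (0.15 log units; within the scatter), though the size is uncertain. Compound 4 is therefore estimated at 200 nM, with a range from 70 nM to 600 nM.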

Compound 4, half-maximal inhibitory concentration: 160 nM
For compound 4 the middle estimate is 1.3-fold (0.10 log units) above the measured one; low and high end bracket the measured number.
By their numbers in this assay, from the lowest: compound 2; then compounds 3, 4 and 1 (each within the scatter of the next, the first and the last beyond it).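

In this assay, replacing 2-fluorophenyl with 3,4-difluorophenyl on the aromatic nitrogen makes no readable difference (a 1.1-fold higher number from compound 3 to compound 4 (0.06 log units; within the scatter)), so the two fluorinated rings cannot be told apart at this position, even though they differ in both the number and the placement of their fluorines. Both rings still carry higher numbers than plain phenyl, and the new comparison confirms this for 3,4-difluorophenyl (a 2.7-fold higher number from compound 2 to compound 4 (0.43 log units; beyond the scatter)), so in these compounds the clear change comes with having fluorine on the ring at all, while the extra fluorine adds nothing that can be read. The chain end can now also be compared directly: 4-methylpiperazin-1-yl in place of piperidin-1-yl stays within the usual scatter (a 1.9-fold lower number from compound 1 to compound 4 (0.29 log units; within the scatter)), so the chain-end exchange shows no clear effect on the number here.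

No measurement available here explains any of these steps. Still open, as far as these compounds go, is how 3-fluorophenyl or 4-fluorophenyl alone would compare, and whether a chlorine or a methoxy group on this ring would behave as fluorine does.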